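A chloro group in place of the methyl ester

The source may report more compounds than this note shows. Statements on the series, on what has been measured and on what is new or still open speak of the compounds shown alone.

Compound 2 `COC(=O)c1cccc(-c2ccc(CN(C)CC3=CC[C@H]4C[C@@H]3C4(C)C)cc2)c1` carries a methoxycarbonyl on its outer phenyl ring. In an assay on HEK293 cells for displacement of a labelled ligand from C-X-C chemokine receptor type 3 (Homo sapiens) (a higher number here means a weaker inhibitor, a lower number a stronger inhibitor), compound 2 gives only a limit, > 316 nM. Compound 1 `CN(CC1=CC[C@H]2C[C@@H]1C2(C)C)Cc1ccc(-c2ccccc2F)cc1` also gives only a limit, > 316 nM. Compound 2 thus stands at the limit of > 316 nM in this assay, at which 2 of the 2 values shown sit. Compound 3 `CN(CC1=CC[C@H]2C[C@@H]1C2(C)C)Cc1ccc(-c2cccc(Cl)c2)cc1` differs from compound 2 by chloro in place of methoxycarbonyl on an aromatic carbon. Among the compounds with values here, with no measured step to build on, the step that the limit leaves unreadable from compound 2 to compound 3 is expected to be small, within the scatter, in either direction. Compound 3 is therefore estimated at 500 nM, within 150 nM to 3000 nM, and may again fall at a limit.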

Compound 3, inhibition constant: 3980 nM
Compound 3: middle estimate off by 8.0-fold (0.90 log units), on the low side; measured number above the stated range.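

No step from compound 2 or compound 1 to compound 3 can be read, since compound 1 and compound 2 each give only a limit: the limit of > 316 nM in this assay, at which 2 of the 3 values shown sit.

The compounds shown leave open how chloro compares with methoxycarbonyl at this position.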